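The compounds below may be only part of what the source reports. "The series", "measured", "known", "first", "only" and "open" are said of these compounds alone.

Three compounds share one core and differ only in the groups attached to it. Compound 1 is `O=C(Nc1cccc(-c2cnco2)c1)C1CCCN(C(=O)c2cc(C(F)(F)F)cc(C(F)(F)F)c2)C1`, compound 2 is `COc1cccc(C(=O)N2CCCC(C(=O)Nc3ccc(Cl)cc3)C2)c1` and compound 3 is `O=C(Nc1ccc(Cl)cc1)C1CCCN(C(=O)c2cc(C(F)(F)F)cc(C(F)(F)F)c2)C1`. In an ADME assay on PC-3 cells (Homo sapiens) for cytotoxicity, read by WST assay, tested at 100 uM (on this read-out higher numbers stand for more inhibition at the one concentration tested (going by the name of the read-out) and lower numbers for less inhibition), compound 1 gives 9%, compound 3 gives 14% and compound 2 gives 0%. Compound 2 thus shows the lowest of the three numbers; its gap to compound 1 lies within the scatter, while its gap to compound 3 lies beyond it. Among the measured compounds shown here, the single measured step between compounds that differ in one place is a number 5 percentage points higher from compound 1 to compound 3 (within the scatter), and it concerns the group on the amide-type nitrogen, not the aromatic carbon in question.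

Compound 4 is `CCN(CC)S(=O)(=O)c1cccc(C(=O)N2CCCC(C(=O)Nc3ccc(Cl)cc3)C2)c1`. Compared with compound 2 the change is diethylsulfamoyl in place of methoxy on an aromatic carbon. For the measured compounds named here, no measured step touches this position, so nothing here points to a shift beyond the scatter, and the one known step was itself within the scatter. The expected step is therefore a number 4 percentage points higher from compound 2 to compound 4 (within the scatter), a step of no real size. For compound 4 the estimate in this assay is 4%, with a range from -6% to 14%.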

Compound 4, a percentage reported as inhibition, at one concentration (the size of the read-out at that concentration, not a potency): 0%
Estimate against measurement, compound 4: 4 percentage points above; measured number inside the range.
By their numbers in this assay, from the lowest: compounds 2, 4, 1 and 3 (each within the scatter of the next, the first and the last beyond it).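

In this assay, among the compounds shown here, the first measured change on this aromatic carbon, meta to a large group, gives no change at the digits printed from compound 2 to compound 4 (within the scatter). The swap is a large one in terms of structure: methoxy has 2 heavy atoms, while diethylsulfamoyl has 8, including a sulfur and a nitrogen, yet the read-out does not respond to it in this pair. Nothing at hand explains why the number stays put.

Going by these compounds, it remains open whether a group of another kind on this aromatic carbon, such as an amine or a carboxylic acid, would move the number beyond the scatter. On these data alone, it is also open whether diethylsulfamoyl would behave the same way with 3-(1,3-oxazol-5-yl)phenyl in place of 4-chlorophenyl on the amide-type nitrogen.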